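Branching the Nitrogen Substituent: Propyl to Isopropyl

This account rests on a few compounds, and the source may have more. Where it says the series, first, only, none or still open, it means among the compounds named here.

Compound 3 `CCCN1CCC2(CC1)OC(OC)Cc1c2cnn1-c1ccccc1` gives 33 nM in an assay for displacement of a labelled ligand from Sigma non-opioid intracellular receptor 1 (Cavia porcellus), read by scintillation counting, with a stated time of 180 min (a higher number here means a weaker inhibitor, a lower number a stronger inhibitor), the highest number among the three measured compounds. In this assay compound 1 `COc1ccc(CN2CCC3(CC2)OC(OC)Cc2c3cnn2-c2ccccc2)cc1` gives 1.5 nM, and compound 2 `COC1Cc2c(cnn2-c2ccccc2)C2(CCN(CCCc3ccccc3)CC2)O1` gives 3.2 nM. The steps of a 22-fold higher number from compound 1 to compound 3 (1.34 log units; beyond the scatter) and a 10-fold higher number from compound 2 to compound 3 (1.01 log units; beyond the scatter) show that the group on the ring nitrogen matters greatly, whereas a 2.1-fold higher number from compound 1 to compound 2 (0.33 log units; beyond the scatter) is modest. Compound 4 `COC1Cc2c(cnn2-c2ccccc2)C2(CCN(C(C)C)CC2)O1` carries isopropyl in place of propyl on an amine nitrogen in a ring. For the measured compounds named here, no measured step swaps one small alkyl for another of the same size, so those steps bear only loosely on this change. The expected step is a 1.2-fold higher number from compound 3 to compound 4 (0.08 log units; within the scatter), not beyond the scatter. Compound 4 is estimated at 40 nM, in a range from 15 nM to 110 nM.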

Compound 4, inhibition constant: 210 nM
The estimate for compound 4 lay 5.3-fold (0.72 log units) below the measured number; the whole stated range lies below it.
By their numbers in this assay, from the lowest: compound 1; then compound 2; then compound 3; then compound 4.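

In this assay rearranging the same three carbons from propyl to isopropyl on the ring nitrogen gives a 6.4-fold higher number from compound 3 to compound 4 (0.80 log units; beyond the scatter) and so shows that this position distinguishes how a small alkyl is joined, not only its atom count. The gap to the larger groups reaches a 66-fold higher number from compound 2 to compound 4 (1.82 log units; beyond the scatter) and a 140-fold higher number from compound 1 to compound 4 (2.15 log units; beyond the scatter) and leaves compound 4 with the highest number of the four. No evidence is available to explain the effect of branching here. On these data alone, whether cyclopropyl or tert-butyl on the ring nitrogen would raise the number further stays open. So does whether branching in a longer chain, such as isobutyl, would carry a similar cost.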